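Working notes: 4-bromophenyl in place of 3-methoxyphenyl

The source may hold more compounds than are shown below. What is called first, only, known or untested is meant among the compounds shown, and "the series" means these compounds.

Within the data shown here, in a functional assay on MDA-MB-231 cells (Homo sapiens) for cytotoxicity, with a stated time of 48 h (a higher number here means a weaker inhibitor, a lower number a stronger inhibitor), compound 1 `COc1cccc(/C=C/C(=O)c2c(OC)cc(OC)cc2OC)c1` gives 8700 nM, the only true number so far. Compound 2 `COc1cc(O)c(C(=O)/C=C/c2ccccc2OC)c(OC)c1` reads > 20000 nM, which is a limit of the assay and not a number.

Compound 3 `COc1cc(OC)c(C(=O)/C=C/c2ccc(Br)cc2)c(OC)c1` has not yet been measured. It keeps the core of compound 1 and carries 4-bromophenyl in place of 3-methoxyphenyl on a double-bonded chain carbon bound to a double-bonded chain carbon. Among the measured compounds shown here, no measured pair isolates this change, so compound 1 at 8700 nM is the sole anchor for the expectation. In this assay the expected 1.5-fold lower number from compound 1 to compound 3 (0.16 log units; within the scatter) is small, leaning towards a stronger inhibitor and hardly clear of the scatter. Compound 3 is estimated at 6000 nM, with an expected range of 2000 nM to 18000 nM.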

Compound 3, half-maximal inhibitory concentration: 11100 nM
The estimate for compound 3 lay 1.9-fold (0.27 log units) below the measured number; measured number inside the range.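

In this assay, the position on a double-bonded chain carbon bound to a double-bonded chain carbon now has its first readable step: a 1.3-fold higher number from compound 1 to compound 3 (0.11 log units; within the scatter). The 4-bromophenyl and 3-methoxyphenyl groups therefore cannot be told apart here, even though the hydrogen-bond acceptor counted on 3-methoxyphenyl is absent from 4-bromophenyl. Compound 2 is held at a limit of the assay and not a number, so steps to it cannot be read: the limit of > 20000 nM in this assay, at which 1 of the 3 values shown sits.

The substituent and its place on the ring change together in this swap, so their contributions remain unseparated; 4-methoxyphenyl or 3-bromophenyl would divide them. Also open, going by these compounds, is whether this position stays as flat in the read-out with an amine or a carboxylic acid on the ring.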